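Acyl aryl exchange from compound 1 to compound 4

The source may report more compounds than this note shows. Statements on the series, on what has been measured and on what is new or still open speak of the compounds shown alone.

Compound 1 `CN(C(=O)NC(=O)c1ccccc1F)c1nc(C(F)(F)F)c(C(=O)N/N=C/c2cc(C(F)(F)F)cc(C(F)(F)F)c2)s1` serves as the reference. Among the measured compounds shown here, in a functional assay on BCG823 cells (Homo sapiens) for inhibition, read by MTT assay, with a stated time of 72 h (on this read-out higher numbers stand for weaker inhibition and lower numbers for stronger inhibition), compound 1 gives 4.23 ug/mL, one of only two numbers so far in the set. Compound 2 `CN(C(=O)NC(=O)c1ccc([N+](=O)[O-])cc1)c1nc(C(F)(F)F)c(C(=O)N/N=C/c2ccc([N+](=O)[O-])cc2)s1` gives 7.45 ug/mL in this assay, a value within the scatter of that of compound 1, so the two are not separable. Compound 3 `CN(C(=O)NC(=O)c1ccc(C(F)(F)F)cc1)c1nc(C(F)(F)F)c(C(=O)N/N=C/c2ccc(C(F)(F)F)cc2)s1` returns only a limit in this assay, > 100 ug/mL, as recorded in the limit of > 100 ug/mL in this assay, at which 1 of the 3 values shown sits. Compound 4 `CN(C(=O)NC(=O)c1ccc(C(F)(F)F)cc1)c1nc(C(F)(F)F)c(C(=O)N/N=C/c2cc(C(F)(F)F)cc(C(F)(F)F)c2)s1` has not been measured. It differs from compound 1 by 4-(trifluoromethyl)phenyl in place of 2-fluorophenyl on a carbonyl carbon. For the measured compounds named here, no measured pair isolates this change, so the expectation leans on compound 3, which carries the same 4-(trifluoromethyl)phenyl group on the carbonyl carbon and gives > 100 ug/mL in this assay. On that basis the step from compound 1 to compound 4 is expected to weaken inhibition, estimated as a 5.9-fold higher number from compound 1 to compound 4 (0.77 log units; beyond the scatter). For compound 4 the expected value in this assay is 25 ug/mL, with a range from 5 ug/mL to 100 ug/mL, and a real chance that only a limit is returned.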

Compound 4, half-maximal inhibitory concentration: 1.77 ug/mL
Compound 4: middle estimate off by 14-fold (1.15 log units), on the high side, outside the stated range (below it).
By their numbers in this assay, from the lowest: compound 4; then compounds 1 and 2 (each within the scatter of the next). At a limit, above all of these: compound 3.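

In this assay, 4-(trifluoromethyl)phenyl in place of 2-fluorophenyl on a carbonyl carbon is tolerated, giving a 2.4-fold lower number from compound 1 to compound 4 (0.38 log units; beyond the scatter), a modest step and the only one here that isolates a change at this position. Compound 3 carries the same 4-(trifluoromethyl)phenyl on the carbonyl carbon, yet its result is a limit and not a number: the limit of > 100 ug/mL in this assay, at which 1 of the 4 values shown sits. This group on the carbonyl carbon therefore does not by itself go with a result at that limit, since compound 4 carries it and gives a measured number, and compound 3 and compound 4 differ only in the other aryl group.

The reading rests on a single step with one partner aryl group, so it may not carry over to other partners. Open too, from the compounds shown here alone, is how this position responds to a 4-fluorophenyl, a pyridine ring or a plain methyl on the carbonyl carbon.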